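Two Measured Compounds and One Awaited Number

The source may hold more compounds than are shown below. What is called first, only, known or untested is meant among the compounds shown, and "the series" means these compounds.

Compound 1, `CC[C@H](C)Nc1nc(Cl)nc(N[C@@H](C)c2ccccc2)n1`, gives 6920 nM in an ADME assay on the whole organism for inhibition, with Oryza sativa as the target, with a stated time of 4 days; a lower number here means a stronger inhibitor, a higher number a weaker inhibitor.
Compound 2, `CC[C@@H](C)Nc1nc(Cl)nc(N[C@H](C)c2ccccc2)n1`, gives 8320 nM in this assay.

Compound 1 holds the lowest of the two numbers, and its nearest neighbour is compound 2, a step of a 1.2-fold higher number from compound 1 to compound 2 (0.08 log units; within the scatter). The two structures share all atoms and bonds and differ only in configuration as drawn, both stereocentres being inverted, and that step rests on (the fact that compounds 1 and 2 differ only in the configuration as drawn); it stays within the scatter, so neither compound can be called the stronger one.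

Compound 3, `CCN(c1nc(Cl)nc(N[C@@H](C)c2ccccc2)n1)C(C)C`, has not yet been measured. It differs from compound 1 by ethyl(isopropyl)amino in place of (sec-butyl)amino on an aromatic carbon. Within the data shown here, no measured step addresses a change of this kind: the single step available, from compound 1 to compound 2, concerns configuration alone and was within the scatter. The expectation for compound 3 therefore cannot lean on a measured precedent, and the estimate is correspondingly broad. Compound 3 is expected to give an estimated 12000 nM, with a range from 3000 nM to 50000 nM. That estimate implies an expected step of a 1.7-fold higher number from compound 1 to compound 3 (0.24 log units; within the scatter).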

Compound 3, half-maximal inhibitory concentration: 537 nM
For compound 3 the middle estimate is 22-fold (1.35 log units) above the measured one, outside the stated range (below it).
By their numbers in this assay, from the lowest: compound 3; then compounds 1 and 2 (each within the scatter of the next).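

In this assay, ethyl(isopropyl)amino in place of (sec-butyl)amino on this aromatic carbon gives a 13-fold lower number from compound 1 to compound 3 (1.11 log units; beyond the scatter), which shows that the number responds strongly to the group at this position, something the earlier pair could not show since its step, a 1.2-fold higher number from compound 1 to compound 2 (0.08 log units; within the scatter), concerned configuration alone. The swap alters several things at once: the entering group has 0 hydrogen-bond donors where the leaving group has 1, it has 6 heavy atoms where the leaving group has 5, and it loses the defined stereocentre of the leaving group. Nothing known about these compounds explains the size of this step.

The compounds shown leave open which of these differences carries the step, since no single compound separates them. A methyl(sec-butyl)amino group at the same position would remove the hydrogen-bond donor while keeping the sec-butyl chain, and a diethylamino group would also have no such donor and no stereocentre, so either would help to tell these differences apart.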